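The source may hold more compounds than are shown below. What is called first, only, known or untested is meant among the compounds shown, and "the series" means these compounds.

Working notes on the series. Compound 1 `O=C(NCCCCCCSSCCCCCCNC(=O)c1cc(-c2ccncc2)n[nH]1)c1cc(-c2ccncc2)n[nH]1` gives 8930 nM in a functional assay on HCT-116 cells (Homo sapiens) for inhibition, read by MTT assay, with a stated time of 96 h; on this read-out higher numbers stand for weaker inhibition of growth and lower numbers for stronger inhibition of growth. Compound 2 `O=C(OCc1ccccc1)SCCCCCCNC(=O)c1cc(-c2ccncc2)n[nH]1` gives 18200 nM in this assay, the highest of the two numbers shown, with compound 1 as the nearest neighbour at a gap beyond the usual scatter. Compound 3 `O=C(CCCCCCS)Nc1ccccc1` is reported only as a limit in this assay, at > 50000 nM (the limit of > 50000 nM in this assay, at which 1 of the 3 values shown sits). Compound 4 `CC(C)C(=O)SCCCCCCNC(=O)c1cc(-c2ccncc2)n[nH]1` has not been measured; it differs from compound 2 by isopropyl in place of benzyloxy on a carbonyl carbon. Within the data shown here, no measured pair of this kind exists in the set, so there is no step to lean on. The expected step from compound 2 to compound 4 is a 1.1-fold higher number from compound 2 to compound 4 (0.04 log units; within the scatter), small and probably within the scatter, in either direction. Compound 4 is estimated at 20000 nM in this assay, with a range from 8000 nM to 50000 nM.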

Compound 4, concentration for 50% growth inhibition: 22700 nM
Beside the measured number, compound 4's estimate is 1.1-fold (0.05 log units) below it, within the range that was stated.
By their numbers in this assay, from the lowest: compound 1; then compounds 2 and 4 (each within the scatter of the next). At a limit, above all of these: compound 3.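

Isopropyl in place of benzyloxy on a carbonyl carbon whose other neighbour is sulfur gives in this assay a 1.2-fold higher number from compound 2 to compound 4 (0.10 log units; within the scatter) and so shows no measurable change. At this position, the read-out therefore does not depend on the six-membered aromatic ring of carbon only, or on the hydrogen-bond acceptor that leaves with benzyloxy. Nothing measured here gives a cause for this flat step.

Going by these compounds, whether an amine or a carboxylic acid on this carbonyl carbon would move the number beyond the scatter remains open. So does the effect of a longer chain there.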